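Replacing 3-methoxyphenyl with 4-(trifluoromethyl)phenyl on the amide

The compounds below may be only part of what the source reports. "The series", "measured", "known", "first", "only" and "open" are said of these compounds alone.

In a functional assay on A549 cells (Homo sapiens) for antiproliferative activity, read by MTT assay, with a stated time of 72 h (a higher number here means a weaker inhibitor, a lower number a stronger inhibitor), compound 1 (`C=CC(=O)Nc1cc(Nc2nccc(NC(=O)c3cccc4ccccc34)n2)c(OC)cc1N1CCN(C)CC1`) gives 6770 nM and compound 2 (`C=CC(=O)Nc1cc(Nc2nccc(NC(=O)c3cccc(OC)c3)n2)c(OC)cc1N1CCN(C)CC1`) gives 6450 nM. Compound 2 thus stands level with compound 1 (a 1.0-fold lower number from compound 1 to compound 2 (0.02 log units; within the scatter)). Compound 3 (`C=CC(=O)Nc1cc(Nc2nccc(NC(=O)c3ccc(C(F)(F)F)cc3)n2)c(OC)cc1N1CCN(C)CC1`) has 4-(trifluoromethyl)phenyl in place of 3-methoxyphenyl on a carbonyl carbon. Going by the values given here, the only measured step at this place is that between compound 1 and compound 2 (a 1.0-fold lower number from compound 1 to compound 2 (0.02 log units; within the scatter)), so no step beyond the scatter is expected in this assay here. The expected change is small (a 1.1-fold lower number from compound 2 to compound 3 (0.03 log units; within the scatter)). Compound 3 is estimated at 6000 nM with 2500 nM to 14000 nM as its expected range.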

Compound 3, half-maximal inhibitory concentration: 7890 nM
Estimate against measurement, compound 3: 1.3-fold (0.12 log units) below, and the stated range covers the measured number.
By their numbers in this assay, from the lowest: compounds 2, 1 and 3 (each within the scatter of the next).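

In this assay, a third aryl group on the carbonyl carbon, 4-(trifluoromethyl)phenyl, stands level with both earlier groups (a 1.2-fold higher number from compound 2 to compound 3 (0.09 log units; within the scatter)) and (a 1.2-fold higher number from compound 1 to compound 3 (0.07 log units; within the scatter)). Across naphthalen-1-yl, 3-methoxyphenyl and 4-(trifluoromethyl)phenyl, this position has so far shown no step beyond the scatter. Nothing available explains this flatness.

From the compounds shown here alone, all three groups are aryl groups, so it stays open whether any group here can move the number. A ring carrying an amine or a carboxylic acid, or an open alkyl chain in place of the ring, could still read differently.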